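The source may hold more compounds than are shown below. What is called first, only, known or untested is meant among the compounds shown, and "the series" means these compounds.

Only two close relatives have been tested so far in an ADME assay on the whole organism (plasma) for pharmacokinetics, with Canis familiaris (Canis lupus familiaris) as the target, read by LC-MS, at a dose of 1 mg/kg by the intravenous route; on this read-out lower numbers stand for slow clearance and higher numbers for fast clearance. Compound 1 `Cc1cc(C(=O)N[C@H]2CCCCC/C=C\[C@@H]3C[C@@]3(C(=O)NS(=O)(=O)C3CC3)NC(=O)[C@@H]3C[C@@H](Oc4nc5cc(F)ccc5nc4C)CN3C2=O)no1` gives 1.17 mL/min/kg, while compound 2 `Cc1cc(C(=O)N[C@H]2CCCCC/C=C\[C@@H]3C[C@@]3(C(=O)NS(=O)(=O)C3CC3)NC(=O)[C@@H]3C[C@@H](Oc4nc5ccccc5nc4C(F)(F)F)CN3C2=O)no1` gives 5.67 mL/min/kg. Compound 2 therefore holds the higher of the two numbers, and its gap to compound 1 lies beyond the usual scatter of repeated measurements.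

Compound 3 `Cc1cc(C(=O)N[C@H]2CCCCC/C=C\[C@@H]3C[C@@]3(C(=O)NS(=O)(=O)C3CC3)NC(=O)[C@@H]3C[C@@H](Oc4nc5cc(F)ccc5nc4C(F)(F)F)CN3C2=O)no1` departs from compound 2 by one small edit: fluoro in place of hydrogen on an aromatic carbon. Among the measured compounds shown here, no measured pair shows this edit alone, so the data offer no direct precedent for its size. For the measured compounds named here, the only guide is the range spanned so far, with compound 2 at 5.67 mL/min/kg as the starting point and compound 1 at 1.17 mL/min/kg as the lower end. A small downward move in this assay is expected, one that stays within the scatter. The expected change is a 1.4-fold lower number from compound 2 to compound 3 (0.15 log units; within the scatter), an estimate that carries real uncertainty. For compound 3, the estimated clearance is 4 mL/min/kg, with a likely range from 1.8 mL/min/kg to 8.5 mL/min/kg.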

Compound 3, clearance: 0.667 mL/min/kg
The estimate for compound 3 lay 6.0-fold (0.78 log units) above the measured number; measured number below the stated range.
By their numbers in this assay, from the lowest: compounds 3 and 1 (each within the scatter of the next); then compound 2.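

In this assay the step of an 8.5-fold lower number from compound 2 to compound 3 (0.93 log units; beyond the scatter) is large for an edit of one heavy atom, so fluoro in place of hydrogen on this aromatic carbon, in a six-membered aromatic ring of carbon only, can clearly change the read-out in this series. The other edit, trifluoromethyl in place of methyl on an aromatic carbon, gives a 1.8-fold lower number from compound 1 to compound 3 (0.24 log units; within the scatter) and so shows no clear change in clearance when the fluoro is present. No measurement at hand speaks to the reason for either step.

Going by these compounds, whether the fluoro step would be as large with methyl in place of trifluoromethyl stays open, as this single pair cannot show whether the result holds beyond compound 2 and compound 3. Also open, on these data alone, is whether another group on the same aromatic carbon, such as chloro, a methoxy group or a nitrile, would give a number close to that of compound 3 or close to that of compound 2.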